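Nitro in place of hydrogen on compound 1

The source may hold more compounds than are shown below. What is called first, only, known or untested is meant among the compounds shown, and "the series" means these compounds.

Compound 1 `COc1cc(OC)c(OC)cc1/C=C/C(=O)c1ccccc1` serves as the reference point for this step. In a functional assay, read by Griess assay, with a stated time of 2.5 h (a higher number here means a weaker inhibitor, a lower number a stronger inhibitor), compound 1 gives 2.01 ug/mL while compound 2 `COc1cc(OC)c(OC)cc1/C=C/C(=O)c1cc(Cl)ccc1O` gives 2.32 ug/mL and compound 3 `COc1cc(OC)c(OC)cc1/C=C/C(=O)c1ccc(C)cc1` gives 2.18 ug/mL on the same read-out. All three values lie within the scatter of each other, so compound 1 stands level with both. Among the compounds with values here, compound 4 `COc1cc(OC)c(OC)cc1/C=C/C(=O)c1cccc([N+](=O)[O-])c1` keeps the core of compound 1 and carries nitro in place of hydrogen on an aromatic carbon, meta to a large group nitro in place of hydrogen on an aromatic carbon as the sole change. The nearest measured change is methyl in place of hydrogen on an aromatic carbon, which gives a 1.1-fold higher number from compound 1 to compound 3 (0.04 log units; within the scatter) for that replacement. The wider aryl exchange gives a 1.2-fold higher number from compound 1 to compound 2 (0.06 log units; within the scatter) and also stays within the scatter. Neither step involves a nitro group, so the range is kept wide. No change beyond the scatter is expected in this assay and the expected outcome is a 1.1-fold higher number from compound 1 to compound 4 (0.04 log units; within the scatter) at most in size. Compound 4 is estimated at 2.2 ug/mL with an expected range from 1.2 ug/mL to 4 ug/mL overall.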

Compound 4, half-maximal inhibitory concentration: 2.35 ug/mL
The estimate for compound 4 lay 1.1-fold (0.03 log units) below the measured number; the range from low to high includes it.
By their numbers in this assay, from the lowest: compounds 1, 3, 2 and 4 (each within the scatter of the next).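

In this assay, nitro in place of hydrogen on an aromatic carbon, meta to a large group, gives a 1.2-fold higher number from compound 1 to compound 4 (0.07 log units; within the scatter). Until now the replacements on this aromatic ring were limited to methyl and the wider exchange for 5-chloro-2-hydroxyphenyl; nitro adds a replacement containing nitrogen and oxygen, and the step still stays within the scatter. No measurement available here bears on why the number holds level at this position.

On these data alone, whether the same holds for an amine or a carboxylic acid on this aromatic carbon remains open, as does the reading for nitro on another carbon of the ring. A longer chain in place of the same hydrogen would test whether any replacement here moves the number in this assay beyond the scatter.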